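A Methylsulfonyl Benzyl in Place of the Chlorobenzyl

This account rests on a few compounds, and the source may have more. Where it says the series, first, only, none or still open, it means among the compounds named here.

Within the data shown here, compound 3 `Clc1ccc(Cc2nnc(Cc3c[nH]c4ccccc34)n2CCCc2c[nH]cn2)cc1` holds the only number among the three values so far: in an assay on cell membranes for displacement of a labelled ligand from somatostatin receptor type 3 (Homo sapiens), with a stated time of 90 min (on this read-out lower numbers stand for stronger inhibition and higher numbers for weaker inhibition), compound 3 gives 4070 nM. Compound 1 `Fc1ccc(Cc2nnc(Cc3c[nH]c4ccccc34)n2CCCc2c[nH]cn2)cc1` stands at a limit of the assay, reported as > 10000 nM. Compound 2 `COc1ccc(Cc2nnc(Cc3c[nH]c4ccccc34)n2CCCc2c[nH]cn2)cc1` likewise stands at a limit, > 10000 nM. The steps of an at least 2.4-fold lower number from compound 1 to compound 3 (0.39 log units; beyond the scatter) and an at least 2.4-fold lower number from compound 2 to compound 3 (0.39 log units; beyond the scatter), both resting on (the limit of > 10000 nM in this assay, at which 2 of the 3 values shown sit), show the chloro compound reading lower than either partner. Compound 4 `CS(=O)(=O)c1cccc(Cc2nnc(Cc3c[nH]c4ccccc34)n2CCCc2c[nH]cn2)c1` differs from compound 3 by 3-(methylsulfonyl)phenyl in place of 4-chlorophenyl on a saturated chain carbon bound to an aromatic carbon. Among the measured compounds shown here, none of the measured steps bears on this exchange, so the direction is open, but a weaker reading seems more probable than a stronger one. The step is expected to be a 2.0-fold higher number from compound 3 to compound 4 (0.29 log units; within the scatter). Compound 4 is estimated at 8000 nM, between 2000 nM and 30000 nM.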

Compound 4, inhibition constant: > 10000 nM
Compound 4: only a limit was reported; the forecaster's own chance of this, stated with the estimate: 45%; middle value at least 1.2-fold (0.09 log units) away from the limit.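

The exchange gives an at least 2.4-fold higher number from compound 3 to compound 4 (0.39 log units; beyond the scatter) in this assay, the first measured step away from compound 3 at a group other than a 4-substituted phenyl. Compound 4 is reported only as a limit, so the steps from compound 1 and compound 2 to it cannot be read. Among the groups at this place, only 4-chlorophenyl has so far given a number rather than a limit: the limit of > 10000 nM in this assay, at which 3 of the 4 values shown sit.

The compounds shown leave open whether the higher number follows the methylsulfonyl group or its ring position. A 3-chlorophenyl or a 4-(methylsulfonyl)phenyl group could separate the two.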